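The source may hold more compounds than are shown below. What is called first, only, known or untested is meant among the compounds shown, and "the series" means these compounds.

Compound 1 `O=c1c2cc([N+](=O)[O-])cnc2sn1-c1ccc([N+](=O)[O-])cc1` gives 11800 nM in an assay for inhibition of histone acetyltransferase KAT2B (Homo sapiens), read by fluorescence (on this read-out higher numbers stand for weaker inhibition and lower numbers for stronger inhibition), the highest of the two numbers in hand. Compound 2 `O=c1c2cc([N+](=O)[O-])cnc2sn1-c1ccc(Br)cc1` gives 4910 nM; the step of a 2.4-fold lower number from compound 1 to compound 2 (0.38 log units; beyond the scatter) is the only measured one, and it concerns bromo in place of nitro at a different place in the structure. Compound 3 `Cc1cnc2sn(-c3ccc([N+](=O)[O-])cc3)c(=O)c2c1` differs from compound 1 as follows: methyl in place of nitro on an aromatic carbon. Among the measured compounds shown here, no measured step touches this place, so the step from compound 1 to compound 3 is expected to be small or none beyond the scatter, a 1.5-fold lower number from compound 1 to compound 3 (0.17 log units; within the scatter). Compound 3 is estimated at 8000 nM, with a range of 2500 nM to 30000 nM.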

Compound 3, half-maximal inhibitory concentration: 15300 nM
The estimate for compound 3 lay 1.9-fold (0.28 log units) below the measured number; the measured number falls inside the stated range.
By their numbers in this assay, from the lowest: compound 2; then compounds 1 and 3 (each within the scatter of the next).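

Methyl in place of nitro, on the six-membered aromatic ring with 1 nitrogen, gives a 1.3-fold higher number from compound 1 to compound 3 (0.11 log units; within the scatter). At this place, then, the nitro group can be lost without a change beyond the scatter, even though methyl brings 0 hydrogen-bond acceptors against the 2 of nitro. Nothing at hand explains this flat step.

Going by these compounds, whether an amine or a carboxylic acid at this place would shift the number remains open. Also open, on these data alone, is whether bromo, on the ring bearing the other nitro in compound 2, would behave alike here.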